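Adding a Bromo Group to Compound 1: Expecting Compound 4

A few compounds are considered here, and "the series" means these few. Any claim that something is new, unique, unknown or untested is made for them only; others in the source may bear on it.

Three compounds were measured in a functional assay on SW1573 cells (Homo sapiens) for inhibition, read by sulforhodamine B assay, with a stated time of 48 h; a higher number here means a weaker inhibitor of growth, a lower number a stronger inhibitor of growth:

Compound 1 `COC(=O)[C@@]1(C)CCC=C2[C@@H]1CC[C@@H](C)[C@]2(C)Cc1c[nH]c2ccccc12` gives 7300 nM.
Compound 2 `COC(=O)[C@@]1(C)CCC=C2[C@@H]1CC[C@@H](C)[C@]2(C)Cc1c[nH]c2ccc(Br)cc12` gives 12000 nM.
Compound 3 `COC(=O)[C@@]1(C)CCC=C2[C@@H]1CC[C@@H](C)[C@]2(C)Cc1c[nH]c2ccc(F)cc12` gives 7300 nM.

Compound 1 stands level with compound 3 at the digits shown, and the two together are the lowest of the three numbers. Among the measured compounds shown here, the only other number, that of compound 2, lies a 1.6-fold higher number from compound 1 to compound 2 (0.22 log units; within the scatter), which is within the scatter, so none of the three can be called stronger or weaker than another.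

Compound 4 `COC(=O)[C@@]1(C)CCC=C2[C@@H]1CC[C@@H](C)[C@]2(C)Cc1c[nH]c2c(Br)cccc12` differs from compound 1 by bromo in place of hydrogen on an aromatic carbon. For the measured compounds named here, two measured steps bear on this change. The step of a 1.6-fold higher number from compound 1 to compound 2 (0.22 log units; within the scatter) also introduces a bromo in place of hydrogen on an aromatic carbon of the shared core, and the step of no change at the digits printed from compound 1 to compound 3 (within the scatter) introduces a fluoro there. Neither step moved the number beyond the scatter. On this basis no step beyond the scatter is expected in this assay for compound 4 either, perhaps a slight drift toward a higher number in line with compound 2.

The estimate for compound 4 is therefore 9000 nM, with a range from 4000 nM to 20000 nM. This estimate amounts to an expected step of a 1.2-fold higher number from compound 1 to compound 4 (0.09 log units; within the scatter).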

Compound 4, concentration for 50% growth inhibition: 14000 nM
Estimate against measurement, compound 4: 1.6-fold (0.19 log units) below, and the stated range covers the measured number.
By their numbers in this assay, from the lowest: compounds 1, 3, 2 and 4 (each within the scatter of the next).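

In this assay, among the compounds shown here, putting bromo on a different aromatic carbon from the one in compound 2, here ortho to a fused ring and meta to a fused ring, gives a 1.9-fold higher number from compound 1 to compound 4 (0.28 log units; within the scatter). Compound 2 gave a 1.6-fold higher number from compound 1 to compound 2 (0.22 log units; within the scatter), so the shared core has now taken bromo at two different places on the same six-membered aromatic ring, and neither change can be told apart from the scatter of repeated measurements. Nothing measured here explains these numbers or shows what a bromo group does at this carbon.

The compounds shown leave open whether this carbon matters for growth inhibition at all, since a change that stays within the scatter gives no sign either way, and a group quite unlike a halogen, such as an amine, a carboxylic acid or a longer chain, might yet produce a step beyond it. They also leave open how fluoro would behave at this same carbon, and whether changes elsewhere on the shared core, away from the aromatic ring, would move the number further than any of these halogens did.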